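This account rests on a few compounds, and the source may have more. Where it says the series, first, only, none or still open, it means among the compounds named here.

Measured so far:
- compound 1 `CC(C)(CO)CNC(=O)c1cc2cc(C#N)ccc2n1Cc1cccc(OC(F)(F)F)c1` gives 62 mL.min-1.g-1 in an in vitro ADME assay on microsomes from liver (Homo sapiens) for metabolic stability, using NADPH; a higher number here means faster removal of the compound, a lower number slower removal
- compound 2 `CCOc1ccc(OC(F)(F)F)cc1Cn1c(C(=O)NCC(C)(C)CO)cc2cc(C#N)ccc21` gives 103 mL.min-1.g-1 in this assay
- compound 3 `CC(C)(CO)CNC(=O)c1cc2cc(C#N)ccc2n1Cc1cc(Cl)cc(Cl)c1` gives 103 mL.min-1.g-1 in this assay

Compound 3 shows the same number as compound 2, and its gap to compound 1 stays within the usual scatter, so these three compounds cannot really be told apart here.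

The next compound is compound 4 `COc1ccc(Br)cc1Cn1c(C(=O)NCC(C)(C)CO)cc2cc(C#N)ccc21`, which has no number yet. It differs from compound 3 on a saturated chain carbon bound to an aromatic nitrogen, where 5-bromo-2-methoxyphenyl stands in place of 3,5-dichlorophenyl 5-bromo-2-methoxyphenyl in place of 3,5-dichlorophenyl on a saturated chain carbon bound to an aromatic nitrogen and the rest of the molecule stays the same.

Within the data shown here, one measured step bears on this change. Ethoxy in place of hydrogen on an aromatic carbon produced a 1.7-fold higher number from compound 1 to compound 2 (0.22 log units; within the scatter) and compound 4 also carries such an oxygen-linked group, here methoxy. Compound 1 and compound 3 carry different groups on that ring as well, and their values stay within the scatter. Among the measured compounds shown here, no measured compound contains bromine, so that part remains untested.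

A step beyond the scatter is therefore not expected, and the estimated step is a 1.0-fold lower number from compound 3 to compound 4 (0.01 log units; within the scatter) with no clear direction. The estimate for compound 4 is 100 mL.min-1.g-1 with an expected range of 50 mL.min-1.g-1 to 200 mL.min-1.g-1 in this measurement.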

Compound 4, intrinsic clearance in microsomes: 104 mL.min-1.g-1
For compound 4 the middle estimate is 1.0-fold (0.02 log units) below the measured one; low and high end bracket the measured number.
By their numbers in this assay, from the lowest: compounds 1, 2, 3 and 4 (each within the scatter of the next).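

In this assay, 5-bromo-2-methoxyphenyl in place of 3,5-dichlorophenyl on a saturated chain carbon bound to an aromatic nitrogen gives a 1.0-fold higher number from compound 3 to compound 4 (0.00 log units; within the scatter), so the two compounds cannot be told apart. This is a larger exchange than the earlier step, which added only ethoxy: both chlorines leave, while a bromine and a methoxy group enter together, bringing one more heavy atom and one hydrogen-bond acceptor, yet no difference can be read from the numbers. Nothing measured here explains why the numbers match.

Bromine and methoxy arrive as one change, so the result cannot show what each contributes alone, and matching numbers could reflect either two parts with little effect or two effects that happen to cancel. Going by these compounds, it also remains open whether an amine or a carboxylic acid on the phenyl ring, or a longer chain linking that ring to the aromatic nitrogen, would produce a step beyond the scatter at this position.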